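Halogen Swap on a Triazole Scaffold: Cytotoxicity Outlook

The compounds below may be only part of what the source reports. "The series", "measured", "known", "first", "only" and "open" are said of these compounds alone.

Compound 1 `O=[N+]([O-])c1cc(CSc2nnc(-c3ccc(Cl)cc3)n2Cc2ccccc2)cc([N+](=O)[O-])c1` gives in an ADME assay on HepG2 cells (Homo sapiens) for cytotoxicity, with a stated time of 48 h (on this read-out lower numbers stand for stronger inhibition and higher numbers for weaker inhibition), only a limit, > 30000 nM.
Compound 2 `O=[N+]([O-])c1cc(CSc2nnc(-c3ccc(Br)cc3)n2Cc2ccccc2)cc([N+](=O)[O-])c1` gives in this assay only a limit, > 30000 nM.
Compound 3 `O=[N+]([O-])c1cc(-c2nnc(SCc3ccc(Br)cc3)n2Cc2ccccc2)cc([N+](=O)[O-])c1` gives in this assay only a limit, > 30000 nM.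

The change from compound 2 to compound 1 is chloro in place of bromo on an aromatic carbon. Its step, a step that the two limits leave unreadable from compound 2 to compound 1, cannot be sized, since both values are limits; this rests on (the limit of > 30000 nM in this assay, at which 3 of the 3 values shown sit), where all three measured values sit. How the core of compound 3 differs from the core of compound 2 is not broken down here; both give only a limit in this assay.

Compound 4 `O=[N+]([O-])c1cc(-c2nnc(SCc3ccc(Cl)cc3)n2Cc2ccccc2)cc([N+](=O)[O-])c1` is not yet measured. It differs from compound 3 by chloro in place of bromo on an aromatic carbon, the same change as from compound 2 to compound 1. For compound 4 a step that the limit leaves unreadable from compound 3 to compound 4 is expected, resting on the unreadable step that the two limits leave unreadable from compound 2 to compound 1 and on (the limit of > 30000 nM in this assay, at which 3 of the 3 values shown sit). Compound 4 is therefore expected to give 50000 nM in this assay, most likely again reported only as a limit, with the range 20000 nM to 150000 nM.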

Compound 4, half-maximal inhibitory concentration: > 30000 nM
Compound 4 was reported as a limit; the forecaster's own chance of this, stated with the estimate: 85%; the middle value does not contradict the limit.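

In this assay compound 4 gives > 30000 nM, which is a limit and not a number. Compound 3 also gives only a limit, so no size can be read for the step between compound 3 and compound 4: the limit of > 30000 nM in this assay, at which 4 of the 4 values shown sit.

The compounds shown leave open whether chloro in place of bromo, or the difference between the cores, changes this read-out at all.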